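The compounds below may be only part of what the source reports. "The series", "measured", "known", "first", "only" and "open" are said of these compounds alone.

Compound 1 `Cc1cc(C(F)(F)F)cc(OCc2c(-c3c(Cl)cccc3Cl)noc2C(C)C)n1` carries the shared core without any acid-bearing side arm; in a functional assay on HEK293 cells for agonist activity at Bile acid receptor (Homo sapiens), read by a luciferase reporter (a lower number here means that less compound is needed, a higher number that more compound is needed for the effect), compound 1 was reported as "not active" (no number reported), with no number given. Compound 2 `CN(Cc1cccc(C(=O)O)c1)c1ccc(OCc2c(-c3c(Cl)cccc3Cl)noc2C2CC2)nc1C(F)(F)F` adds a (3-carboxybenzyl)(methyl)amino arm to the pyridine ring, and in this assay compound 2 gives 2 nM, the lowest of the two numbers recorded. Compound 3 `CN(Cc1ccc(C(=O)NCCS(=O)(=O)O)cc1)c1ccc(OCc2c(-c3c(Cl)cccc3Cl)noc2C2CC2)nc1C(F)(F)F` keeps the same core but ends its arm in a taurine-type amide instead of a free carboxylic acid; in this assay compound 3 gives 925 nM, a number far beyond the usual scatter away from that of compound 2.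

Compound 4 `CC(Oc1ccc(C(=O)O)cc1)c1ccc(OCc2c(-c3c(Cl)cccc3Cl)noc2C2CC2)nc1C(F)(F)F` is the next variation on compound 2. The change is 1-(4-carboxyphenoxy)ethyl in place of (3-carboxybenzyl)(methyl)amino on an aromatic carbon. The carboxylic acid is kept, but the linker to the pyridine changes from a methylated nitrogen to an oxygen on a methyl-bearing carbon, and the acid moves to the other side of its phenyl ring.

Going by the values given here, no single-place step between measured compounds is available to calibrate this. Since compound 2 with a free acid gives 2 nM while compound 3 without one gives 925 nM, the acid-retaining compound 4 is expected to stay potent, with a modest rise in the number; the estimated step of a 5.0-fold higher number from compound 2 to compound 4 (0.70 log units; beyond the scatter) is expected to be small. Compound 4 is estimated at 10 nM, within 2 nM to 60 nM.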

Compound 4, half-maximal effective concentration: 611 nM
Estimate against measurement, compound 4: 61-fold (1.79 log units) below, and the stated range ends below it.
By their numbers in this assay, from the lowest: compound 2; then compounds 4 and 3 (each within the scatter of the next).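

At this position, on an aromatic carbon ortho to a trifluoromethyl group, the arm turns out to matter far more than the presence of a carboxylic acid on it: exchanging (3-carboxybenzyl)(methyl)amino for 1-(4-carboxyphenoxy)ethyl gives a 310-fold higher number from compound 2 to compound 4 (2.49 log units; beyond the scatter) in this assay. The two arms have equal counts of heavy atoms, hydrogen-bond donors and hydrogen-bond acceptors, and each holds one six-membered aromatic ring of carbon only, so those counts do not separate them. Going by these compounds alone, the size of the step therefore sets this arm's composition and layout apart as decisive, which no earlier compound could show, as no earlier pair differed in one place only.

This single step changes the linker atoms and the acid's place on its phenyl ring together, so it cannot assign the loss to either change. Where a (4-carboxybenzyl)(methyl)amino arm or a 1-(3-carboxyphenoxy)ethyl arm would fall in this assay stays open, and either would divide the step into its parts, while nothing shown accounts for the size of the step itself.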